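The compounds below may be only part of what the source reports. "The series", "measured", "known", "first", "only" and "open" are said of these compounds alone.

Measured so far in an assay on isolated protein for inhibition of Discoidin domain-containing receptor 2 (Homo sapiens), read by ELISA, with a stated time of 60 min; a higher number here means a weaker inhibitor, a lower number a stronger inhibitor:

Compound 1, `CCn1cc(-c2n[nH]c3cc(-c4cc(C(=O)Nc5cccc(C(F)(F)F)c5)ccc4C)ccc23)cn1`: 2.6 nM
Compound 2, `Cc1ccc(C(=O)Nc2cccc(C(F)(F)F)c2)cc1-c1ccc2c(-c3cnn(CC(=O)N(C)C)c3)n[nH]c2c1`: 2.7 nM
Compound 3, `Cc1ccc(C(=O)Nc2cccc(C(F)(F)F)c2)cc1-c1ccc2c(-c3cnn(C4CCCCO4)c3)n[nH]c2c1`: 5.2 nM

On the numbers alone compound 3 carries the highest of the three values, yet the steps leading to it, a 2.0-fold higher number from compound 1 to compound 3 (0.30 log units; within the scatter) and a 1.9-fold higher number from compound 2 to compound 3 (0.28 log units; within the scatter), both lie within the scatter, as does a 1.0-fold higher number from compound 1 to compound 2 (0.02 log units; within the scatter), so the three compounds are not told apart by this assay.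

Compound 4, `Cc1ccc(C(=O)Nc2cccc(C(F)(F)F)c2)cc1-c1ccc2c(-c3cnn(C4CCN(C)CC4)c3)n[nH]c2c1`, has not yet been measured. It differs from compound 3 by 1-methylpiperidin-4-yl in place of oxan-2-yl on an aromatic nitrogen. Every measured step in this set changes the same group on the aromatic nitrogen of the shared core, and none of them moved the number beyond the scatter. The new group is again a six-membered non-aromatic ring with one hetero atom and one hydrogen-bond acceptor, so no step beyond the scatter is expected in this assay either.

Compound 4 is therefore estimated at 4 nM, with a range of 1.5 nM to 12 nM, which means an expected step of a 1.3-fold lower number from compound 3 to compound 4 (0.11 log units; within the scatter).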

Compound 4, half-maximal inhibitory concentration: 3.8 nM
Estimate against measurement, compound 4: 1.1-fold (0.02 log units) above; measured number inside the range.
By their numbers in this assay, from the lowest: compounds 1, 2, 4 and 3 (each within the scatter of the next).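

In this assay, 1-methylpiperidin-4-yl on the aromatic nitrogen places a ring nitrogen where the oxan-2-yl group of compound 3 has a ring oxygen, and the number stays within the scatter (a 1.4-fold lower number from compound 3 to compound 4 (0.14 log units; within the scatter)). The same holds against the two open-chain groups, (dimethylcarbamoyl)methyl (a 1.4-fold higher number from compound 2 to compound 4 (0.15 log units; within the scatter)) and ethyl (a 1.5-fold higher number from compound 1 to compound 4 (0.16 log units; within the scatter)), so all four groups at this position remain untold apart. Nothing in the data shown accounts for this lack of separation.

Going by these compounds, what remains open is whether a carboxylic acid, a longer chain ending in a primary amine, or a plain hydrogen on this nitrogen would move the number beyond the scatter. The compounds also leave open whether a phenyl ring here would do the same.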